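Swapping the side chain group on a benzothiazole-imine core

The source may report more compounds than this note shows. Statements on the series, on what has been measured and on what is new or still open speak of the compounds shown alone.

Of the compounds shown here, three have been tested in a functional assay on the whole organism with Rattus norvegicus as the target; a higher number here means that more compound is needed for the effect, a lower number that less compound is needed. Compound 1, `CC(C)(C)Oc1ccc2nc(N)sc2c1`, gives a value of > 10 mg/kg, which is a limit of the assay rather than a number. Compound 2, `Nc1nc2ccc(OCC(F)(F)F)cc2s1`, gives 6.5 mg/kg. Compound 3, `CNS(=O)(=O)CCn1c(=N)sc2cc(OC(F)(F)F)ccc21`, gives 4 mg/kg, the lowest of the two numbers; compound 2 is within the scatter of it. Going by the values given here, the one measured step, an at least 1.5-fold lower number from compound 1 to compound 2 (0.18 log units; that floor lies within the scatter), concerns the group on the oxygen on the aromatic ring.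

Compound 4, `C[S+]([O-])CCCn1c(=N)sc2cc(OC(F)(F)F)ccc21`, differs from compound 3 elsewhere: a group of 4 heavy atoms (2 carbon, 1 oxygen, 1 sulfur; no ring) in place of a group of 5 heavy atoms (1 carbon, 1 nitrogen, 2 oxygen, 1 sulfur; no ring), on a saturated chain carbon, two bonds along the chain from an aromatic nitrogen. No measured step touches this part of the molecule, so nothing shown gives a direction for this change. The change expected from compound 3 to compound 4 in this assay is therefore no change at the digits printed from compound 3 to compound 4 (within the scatter), that is, none beyond the scatter. Compound 4 is expected to give about 4 mg/kg in this assay, with a range from 1.5 mg/kg to 12 mg/kg.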

Compound 4, dose for half-maximal effect: 2.3 mg/kg
Compound 4: middle estimate off by 1.7-fold (0.24 log units), on the high side, within the range that was stated.
By their numbers in this assay, from the lowest: compounds 4, 3 and 2 (each within the scatter of the next, the first and the last beyond it). At a limit, above all of these: compound 1.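

Going by these compounds alone, the only measured step at this place, on a saturated chain carbon, two bonds along the chain from an aromatic nitrogen, is a 1.7-fold lower number from compound 3 to compound 4 (0.24 log units; within the scatter) in this assay and so shows no change beyond the scatter. The methylsulfamoyl group, which carries a hydrogen-bond donor, can therefore give way to a group with fewer heavy atoms and no hydrogen-bond donor without a shift beyond the scatter in this whole-animal read-out. Nothing measured here offers an explanation for this result.

From the compounds shown here alone, whether an amine, a carboxylic acid or a longer chain at this place would move the number beyond the scatter remains open. Also open, going by these compounds, is whether this swap would read the same in a compound with a tert-butyl or 2,2,2-trifluoroethyl group on the oxygen.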